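This account rests on a few compounds, and the source may have more. Where it says the series, first, only, none or still open, it means among the compounds named here.

Compound 1, `C[Si](C)(C)c1cn(C[C@H](O)[C@H]2OC(=O)C(OCc3ccccc3)=C2OCc2ccccc2)nn1`: 19200 nM
Compound 2, `O=C1O/C(=C\Cn2cc(-c3cccc(O)c3)nn2)C(OCc2ccccc2)=C1OCc1ccccc1`: 23300 nM

Of the compounds shown here, two sharing the same core have been tested in a functional assay on A549 cells (Homo sapiens) for antiproliferative activity, read by MTT assay, with a stated time of 72 h; on this read-out higher numbers stand for weaker inhibition and lower numbers for stronger inhibition. In this assay compound 1 gives 19200 nM, the lowest of the two numbers shown. Compound 2 gives 23300 nM, and this number lies within the scatter of compound 1, so the two compounds cannot be set apart by these measurements; both sit in the weak range.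

Compound 3, `CCCCCc1ccc(-c2cn(C[C@H](O)[C@H]3OC(=O)C(OCc4ccccc4)=C3OCc3ccccc3)nn2)cc1`, is the next compound to be measured. It differs from compound 1 in one place: a group of 11 heavy atoms (11 carbon; one six-membered aromatic ring of carbon only) in place of a group of 4 heavy atoms (3 carbon, 1 silicon; no ring), on an aromatic carbon. Among the measured compounds shown here, no measured pair shows this kind of change, so its effect has to be guessed. Compound 2, which also carries a six-membered aromatic ring of carbon only on its five-membered aromatic ring with 3 nitrogen, gives a number close to compound 1, which argues against any large swing. A modest step toward a lower number is expected from compound 1 to compound 3, a 2.1-fold lower number from compound 1 to compound 3 (0.33 log units; beyond the scatter). Compound 3 is estimated to give about 9000 nM in this assay, with a likely range from 2500 nM to 30000 nM.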

Compound 3, half-maximal inhibitory concentration: 6220 nM
Beside the measured number, compound 3's estimate is 1.4-fold (0.16 log units) above it, within the range that was stated.
By their numbers in this assay, from the lowest: compound 3; then compounds 1 and 2 (each within the scatter of the next).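

In this assay, the aromatic carbon of the five-membered aromatic ring with 3 nitrogen proves to be a place where a change can be read: 4-pentylphenyl in place of the small silicon-bearing group of compound 1 gives a 3.1-fold lower number from compound 1 to compound 3 (0.49 log units; beyond the scatter). This is the first step shown that lies beyond the scatter, so this position does respond to what it carries, and it accepts a much larger group, one with a six-membered aromatic ring of carbon only, with a lower number rather than a higher one. No measurement at hand explains this step.

The step brings in a ring and a chain at once, so the compounds shown cannot tell whether the lower number goes with the aromatic ring itself or with the pentyl chain on it. A plain phenyl group, a shorter chain such as ethyl, a longer chain such as octyl, or an amine at the end of the chain would each be needed to separate those two parts.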